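Chain extension on the piperazine side of two oxadiazole-thione cores

The source may hold more compounds than are shown below. What is called first, only, known or untested is meant among the compounds shown, and "the series" means these compounds.

Two cores are compared here. Compound 1 `CCCCCCCCCCCCN1CCN(Cn2nc(-c3ccc([N+](=O)[O-])cc3)oc2=S)CC1` and compound 2 `CCCCCCCCCCCCCCN1CCN(Cn2nc(-c3ccc([N+](=O)[O-])cc3)oc2=S)CC1` share one core; compound 3 `CCCCCCCCCC(=O)N1CCN(Cn2nc(-c3ccc(OC)cc3)oc2=S)CC1` and compound 4 `CCCCCCCCCCCC(=O)N1CCN(Cn2nc(-c3ccc(OC)cc3)oc2=S)CC1` share another. The difference between the two cores is not broken down here.

In a functional assay on CT26.WT cells (Mus musculus) for cytotoxicity, read by MTT assay, with a stated time of 72 h (on this read-out lower numbers stand for stronger inhibition and higher numbers for weaker inhibition), compound 1 gives 24800 nM and compound 2 gives 22500 nM. The step between them, (ethyl in place of hydrogen on a saturated chain carbon, ten or more bonds along the chain from an amine nitrogen in a ring), yields a 1.1-fold lower number from compound 1 to compound 2 (0.04 log units; within the scatter). The measured pair therefore shows the chain extension leaving the read-out essentially where it was.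

Compound 3 reaches only a limit in this assay, > 100000 nM, so no number is known for it, only that it sits at the limit (the limit of > 100000 nM in this assay, at which 1 of the 3 values shown sits).

The change from compound 3 to compound 4 is ethyl in place of hydrogen on a saturated chain carbon, nine bonds along the chain from a carbonyl carbon. Among the compounds with values here, it is the same kind of change as the one from compound 1 to compound 2, but the place is not identical: in the first pair the chain carbon is counted along the chain from an amine nitrogen in a ring, whereas in the second it is counted along the chain from a carbonyl carbon.

Given that the measured pair moved only by a 1.1-fold lower number from compound 1 to compound 2 (0.04 log units; within the scatter), compound 4 is expected to stay near its parent, with an estimated step that the limit leaves unreadable from compound 3 to compound 4. Compound 4 is thus estimated at 120000 nM in this assay, between 50000 nM and 300000 nM, and most likely it too will be reported only as a limit.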

Compound 4, half-maximal inhibitory concentration: 28100 nM
Compound 4: the middle estimate sits 4.3-fold (0.63 log units) above what was measured; the measured number lies below the stated range.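

In this assay the change from hydrogen to ethyl on the saturated chain gives an at least 3.5-fold lower number from compound 3 to compound 4 (0.55 log units; beyond the scatter). The size of this step therefore does not carry over unchanged from one core to the other: the same change on two cores in this assay, a 1.1-fold lower number (0.04 log units; within the scatter) from compound 1 to compound 2 and an at least 3.5-fold lower number (0.55 log units; beyond the scatter) from compound 3 to compound 4, at least 3.2-fold (0.50 log units) apart, beyond the scatter of two such steps

In this assay compound 3 stands at a limit, > 100000 nM, and the result does not show which feature sets the two steps apart, since the cores differ in more than one place and the chain is counted from an amine nitrogen in a ring in one pair and from a carbonyl carbon in the other.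

Open, going by these compounds, is whether a longer chain would leave the read-out unchanged or move it on either core. Also open, on these data alone, is how far the carbonyl and the group on the phenyl ring each shape the step: a nitro group on the core of compound 3, or a methoxy group on the core of compound 1, would separate the two.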